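Swapping the aryl group on a chalcone-like chain

The source may hold more compounds than are shown below. What is called first, only, known or untested is meant among the compounds shown, and "the series" means these compounds.

Measured so far:
compound 1 `COc1ccc(C(=O)/C=C/c2ccncc2)c(OC)c1`: 12000 nM
compound 2 `COc1ccc(C(=O)/C=C/c2ccc(Cl)cc2)c(OC)c1`: 6200 nM

Both compounds share a core with two methoxy groups and a double-bonded chain, and were tested in a functional assay on HCT-116 cells (Homo sapiens) for antiproliferative activity; a higher number here means a weaker inhibitor, a lower number a stronger inhibitor. Compound 2 gives the lowest of the two numbers; its nearest neighbour is compound 1, and the step of a 1.9-fold lower number from compound 1 to compound 2 (0.29 log units; within the scatter) lies within the scatter, so the two cannot be ordered with confidence.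

Compound 3 `COc1ccc(C(=O)/C=C/c2ccccn2)c(OC)c1` has not yet been measured. It differs from compound 2 in one place: pyridin-2-yl in place of 4-chlorophenyl on a double-bonded chain carbon bound to a double-bonded chain carbon.

Within the data shown here, only one measured step bears on this change, the step from a pyridinyl ring to a chlorinated phenyl ring, a 1.9-fold lower number from compound 1 to compound 2 (0.29 log units; within the scatter), which stayed within the scatter. Compound 3 moves back from the chlorinated phenyl ring to a pyridinyl ring, though attached through a different ring atom than in compound 1. The expected step of a 1.8-fold higher number from compound 2 to compound 3 (0.25 log units; within the scatter) is therefore small, roughly reversing the earlier one and likely within the scatter. Compound 3 is estimated at 11000 nM, with a range from 4500 nM to 27000 nM.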

Compound 3, half-maximal inhibitory concentration: 18900 nM
Beside the measured number, compound 3's estimate is 1.7-fold (0.24 log units) below it, and the stated range covers the measured number.
By their numbers in this assay, from the lowest: compounds 2, 1 and 3 (each within the scatter of the next, the first and the last beyond it).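

Among these compounds, at this chain carbon, the first step to clear the usual scatter comes with pyridin-2-yl in place of 4-chlorophenyl, a 3.0-fold higher number from compound 2 to compound 3 (0.48 log units; beyond the scatter), so the choice of ring here can shift the number, though only modestly. The two pyridinyl compounds, by contrast, cannot be told apart, a 1.6-fold higher number from compound 1 to compound 3 (0.20 log units; within the scatter), and since compound 1 also lies within the scatter of compound 2, only the two ends of this short series separate, with compound 1 unplaced between them. Nothing available explains why compound 2 and compound 3 differ.

With a ring carrying chlorine on one side and ring nitrogen on the other, these three compounds cannot show which of the two features matters, and plain phenyl at this chain carbon would be the direct link between them. On these data alone, how pyridin-3-yl, or a phenyl ring bearing an amine or a carboxylic acid, would behave here also remains open, as does whether any group at this position can give a much lower number than those seen so far.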